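This account rests on a few compounds, and the source may have more. Where it says the series, first, only, none or still open, it means among the compounds named here.

Three compounds built on one shared core have been examined in an ADME assay on Vero cells (Chlorocebus sabaeus) for cytotoxicity, with a stated time of 7 days; on this read-out higher numbers stand for lower toxicity in this test and lower numbers for higher toxicity in this test. Compound 1 `COc1cccc(CN2C(=O)CN(C(=O)c3cc4cc(OC)ccc4[nH]3)C[C@@H]2COCc2ccccc2)c1` gives a value that is only a limit of the test, > 10000 nM. Compound 2 `COc1ccc2[nH]c(C(=O)N3CC(=O)N(Cc4ccccc4)[C@@H](COCc4ccccc4)C3)cc2c1` likewise reaches only a limit, > 30000 nM. Compound 3 `COc1ccc2[nH]c(C(=O)N3CC(=O)N(Cc4ccccc4)[C@@H](N4CCC(Cc5ccccc5)CC4)C3)cc2c1` also reaches only a limit, > 30000 nM. For the measured compounds named here, the single step between measured compounds that differ in one place, a step that the two limits leave unreadable from compound 1 to compound 2, has no readable size, as both of its ends are limits. Compound 2 therefore stands at the higher of the two limits seen here; the limit of > 30000 nM in this assay, at which 2 of the 3 values shown sit, shows two of the three values sitting there, and the limit of > 10000 nM in this assay, at which 1 of the 3 values shown sits, covers the remaining one. Compound 4 `COc1ccc2[nH]c(C(=O)N3CC(=O)N(Cc4ccccc4)[C@@H](CN4CCC(C(C)C)CC4)C3)cc2c1` differs from compound 2 in one place: 4-isopropylpiperidin-1-yl in place of benzyloxy on a saturated chain carbon bound to a saturated ring carbon. Going by the values given here, no measured step bears on this change, and no measured value here offers a number to build on. The step from compound 2 to compound 4 is expected to be a number no higher from compound 2 to compound 4 (the limit leaves the size open), within the scatter. Compound 4 is thus expected to give 30000 nM, in a range from 10000 nM to 60000 nM.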

Compound 4, half-maximal cytotoxic concentration: 3800 nM
The estimate for compound 4 lay 7.9-fold (0.90 log units) above the measured number, and the stated range ends above it.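

Compound 4 is the only compound shown that gives a real number rather than a limit, so the group on this saturated chain carbon can change the result in this assay. Replacing (benzyloxy)methyl with (4-isopropylpiperidin-1-yl)methyl gives an at least 7.8-fold lower number from compound 2 to compound 4 (0.89 log units; beyond the scatter), and on this read-out the lower number stands for higher toxicity in this test; the true size may be larger, as the value of compound 2 is only a limit. Nothing shown gives a cause for this step.

Going by these compounds, with only this one replacement, it stays open whether the change goes with the piperidine ring itself or with its isopropyl group. A plain piperidin-1-yl or a morpholin-4-yl at the same place would help to separate the two.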